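The compounds below may be only part of what the source reports. "The series", "measured", "known", "first", "only" and "open" are said of these compounds alone.

Compound 1 `Cc1nnc(SCc2cc(=O)c3cc(Cl)ccc3o2)o1` in a functional assay on MCF7 cells (Homo sapiens) for cytotoxicity, read by MTT assay, with a stated time of 72 h (on this read-out lower numbers stand for stronger inhibition and higher numbers for weaker inhibition), gives > 25000 nM, which is a limit of the assay rather than a number.
Compound 2 `Cc1cc(C)n2nc(SCc3cc(=O)c4cc(Cl)ccc4o3)nc2n1` in this assay gives > 25000 nM, also a limit.
Compound 3 `Cc1nnc(SCc2cc(=O)c3ccccc3o2)o1` in this assay gives > 25000 nM, again a limit.

Compound 1 and compound 3 differ in one place only: hydrogen in place of chloro on an aromatic carbon. Both values are limits, and so the step comes out as a step that the two limits leave unreadable from compound 1 to compound 3. How the core of compound 2 differs from the core of compound 1 is not broken down here. Compound 4 `Cc1cc(C)n2nc(SCc3cc(=O)c4ccccc4o3)nc2n1` has not yet been measured in this assay. Among the compounds with values here, it differs from compound 2 by hydrogen in place of chloro on an aromatic carbon, the same change as the one between compound 1 and compound 3, the surroundings of the place being described in identical words. Within the data shown here, what the measured compounds show is summed up by the limit of > 25000 nM in this assay, at which 3 of the 3 values shown sit, so no measured step gives a size to this change. The expectation for compound 4 rests on that alone. For compound 4 the step is expected to be a step that the limit leaves unreadable from compound 2 to compound 4. Compound 4 is therefore expected at about 40000 nM, most likely again reported only as a limit.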

Compound 4, half-maximal inhibitory concentration: > 25000 nM
Compound 4: no number, only a limit; the forecaster's own chance of this, stated with the estimate: 85%; the middle value lies beyond the limit too.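

No new step can be read: compound 2 and compound 4, which differ by hydrogen in place of chloro on an aromatic carbon, are both reported only as limits of the assay, not as numbers. The compounds shown leave open whether this change affects cytotoxicity at all, and what the real potency of any of them is: the limit of > 25000 nM in this assay, at which 4 of the 4 values shown sit.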